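Halogen Swap on an Aryl Ring: Expected Cell Effect

A few compounds are considered here, and "the series" means these few. Any claim that something is new, unique, unknown or untested is made for them only; others in the source may bear on it.

Compound 1 `COc1ccc(-c2cc3ccc(OCCCCn4cc(CNC(=O)CCCCC5CCSS5)nn4)cc3oc2=O)cc1` gives 48.6% in a functional assay on PC-12 cells (Rattus norvegicus) for cytotoxicity, read by MTT assay, with stated times of 3 h and 2 h, tested at 10 uM; on this read-out lower numbers stand for a weaker effect and higher numbers for a stronger effect at the one concentration tested.
Compound 2 `O=C(CCCCC1CCSS1)NCc1cn(CCCCOc2ccc3cc(-c4ccc(Br)cc4)c(=O)oc3c2)nn1` gives 42.6% in this assay.

Only these two compounds have numbers. Among the measured compounds shown here, compound 2 sits at one end of the pair, with compound 1 as its sole neighbour; the step of a number 6 percentage points lower from compound 1 to compound 2 (within the scatter) lies within the scatter, so the two compounds cannot be told apart on this read-out.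

Compound 3 `O=C(CCCCC1CCSS1)NCc1cn(CCCCOc2ccc3cc(-c4ccc(Cl)c(Cl)c4)c(=O)oc3c2)nn1` has not yet been measured. It differs from compound 2 in one place: 3,4-dichlorophenyl in place of 4-bromophenyl on an aromatic carbon. For the measured compounds named here, the only measured step that bears on this change is the one between compound 1 and compound 2, where a different group on the same aryl ring produced a number 6 percentage points lower from compound 1 to compound 2 (within the scatter), a movement within the scatter. Exchanging one halogenated aryl group for another is therefore expected to give no step beyond the scatter, a number 0.4 percentage points higher from compound 2 to compound 3 (within the scatter). Compound 3 is thus estimated at 43%, with a range of 30% to 56%.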

Compound 3, a percentage reported as activity, at one concentration (the size of the read-out at that concentration, not a potency): 58.9%
Estimate against measurement, compound 3: 15.9 percentage points below; measured number outside the range, above it.
By their numbers in this assay, from the lowest: compounds 2 and 1 (each within the scatter of the next); then compound 3.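

This position on the aryl ring does respond to the group it carries: 3,4-dichlorophenyl in place of 4-bromophenyl gives a number 16.3 percentage points higher from compound 2 to compound 3 (beyond the scatter) in this assay. Replacing 4-methoxyphenyl with the same group also clears the scatter, giving a number 10.3 percentage points higher from compound 1 to compound 3 (beyond the scatter), whereas the earlier bromo and methoxy compounds could not be told apart, so the dichlorophenyl compound now stands alone at the top of the three. No measurement shown gives a reason for this difference.

The compounds shown leave open whether both chlorine atoms are needed, which a single 4-chlorophenyl or 3-chlorophenyl group on the same carbon could test. They also leave open how a quite different substituent on this aryl ring, such as an amine or a carboxylic acid, would read out.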